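A few compounds are considered here, and "the series" means these few. Any claim that something is new, unique, unknown or untested is made for them only; others in the source may bear on it.

Working notes on the chromone amide series, step from compound 2 to compound 3.

Of the compounds shown here, two have numbers so far. Compound 1 `COc1ccc2c(=O)c(/C=C/C(=O)NCc3ccccc3F)coc2c1` carries a 2-fluorobenzyl group on the amide nitrogen; in a functional assay (QGY7701 cells, Homo sapiens) for inhibition, read by MTT assay, with a stated time of 48 h (a lower number here means a stronger inhibitor, a higher number a weaker inhibitor), compound 1 gives 34000 nM. Compound 2 `COc1ccc2c(=O)c(/C=C/C(=O)NCc3ccc(C)cc3)coc2c1` carries a 4-methylbenzyl group instead; in this assay compound 2 gives 10200 nM. Among the compounds with values here, the one step between them, a 3.3-fold lower number from compound 1 to compound 2 (0.52 log units; beyond the scatter), is the only measured change, and it places compound 2 as the lower of the two numbers, with compound 1 the only neighbour.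

Compound 3 `COc1ccc2c(=O)c(/C=C/C(=O)Nc3ccc(Cl)cc3)coc2c1` is not yet measured. Its difference from compound 2 is 4-chlorophenyl in place of 4-methylbenzyl on an amide-type nitrogen. Within the data shown here, no measured step bears on this change directly: the step from compound 1 to compound 2 swaps one aryl substitution pattern for another on a benzyl group, whereas here the saturated chain carbon is dropped and the aryl ring sits directly on the amide nitrogen. The size of that one step, modest and beyond the scatter, is the only scale available. A change of comparable size is therefore expected, in either direction, with the number for compound 3 estimated near 8000 nM, in a range from 2500 nM to 30000 nM, which corresponds to an expected step of a 1.3-fold lower number from compound 2 to compound 3 (0.11 log units; within the scatter).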

Compound 3, half-maximal inhibitory concentration: > 100000 nM
Compound 3 gave a limit, no number; the forecaster's own chance of this, stated with the estimate: 10%; at least 12-fold (1.09 log units) between middle value and limit.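

In this assay compound 3 reaches only a limit of the assay, not a number: the limit of > 100000 nM in this assay, at which 1 of the 3 values shown sits.

The two compounds with a saturated chain carbon on the amide-type nitrogen both give numbers, whereas compound 3, with its 4-chlorophenyl ring on that nitrogen, does not, and the change from 4-methylbenzyl gives an at least 9.8-fold higher number from compound 2 to compound 3 (0.99 log units; beyond the scatter), while the change from 2-fluorobenzyl gives an at least 2.9-fold higher number from compound 1 to compound 3 (0.46 log units; beyond the scatter). Within the data shown here, until now the series showed only a modest effect of swapping one substituted benzyl group for another, so this is the first sign that the group on the amide-type nitrogen can take the read-out out of the measurable range altogether. Both steps are beyond the scatter, and the larger one starts from compound 2, although each is a bound on the true size, not a measured size.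

The change removes the saturated chain carbon and also exchanges the ring substituent, so the compounds shown cannot assign the loss to either alteration alone. A 4-chlorobenzyl group on the same nitrogen would separate the two, and a longer chain such as 2-phenylethyl remains an open question on the other side of the benzyl length.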